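A few compounds are considered here, and "the series" means these few. Any claim that something is new, unique, unknown or untested is made for them only; others in the source may bear on it.

Measured so far in a functional assay on MCF7 cells (Homo sapiens) for cytotoxicity, read by MTT assay, with a stated time of 48 h; a higher number here means a weaker inhibitor, a lower number a stronger inhibitor:
compound 1, `C=CCNC(=S)N/N=C\c1ccnc2ccccc12`, gives 970 nM
compound 2, `O=[N+]([O-])c1ccc(NC(=S)N/N=C\c2ccnc3ccccc23)cc1`, gives 810 nM

Compound 1 and compound 2 give numbers that lie within the usual scatter of each other, so on these two results compound 1 does not stand apart. Compound 3, `S=C(N/N=C\c1ccnc2ccccc12)Nc1ccc(Br)cc1`, is not yet measured. It differs from compound 1 in one place: 4-bromophenyl in place of allyl on an amide-type nitrogen. Compound 2 likewise carries an aromatic ring in place of the allyl and gives 810 nM, close to compound 1. On that ground the step of a 1.1-fold lower number from compound 1 to compound 3 (0.06 log units; within the scatter) is expected to be none beyond the scatter. Compound 3 is estimated at 850 nM, within a range from 400 nM to 1800 nM.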

Compound 3, half-maximal inhibitory concentration: 990 nM
Compound 3: the middle estimate sits 1.2-fold (0.07 log units) below what was measured; the measured number falls inside the stated range.
By their numbers in this assay, from the lowest: compounds 2, 1 and 3 (each within the scatter of the next).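

In this assay, 4-bromophenyl in place of allyl on the amide-type nitrogen gives a 1.0-fold higher number from compound 1 to compound 3 (0.01 log units; within the scatter), so this position holds a larger aromatic ring with the number staying within the scatter. On that ring, bromo in place of nitro gives a 1.2-fold higher number from compound 2 to compound 3 (0.09 log units; within the scatter), so these two ring groups cannot be told apart here. Nothing measured on these compounds accounts for this result.

Still open, as far as these compounds go, is whether a longer chain on that nitrogen, or an amine or carboxylic acid on the aromatic ring, would shift the number beyond the scatter.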